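Bromophenyl to dichlorophenyl in a bis-benzylidene cyclohexanone series

The compounds below may be only part of what the source reports. "The series", "measured", "known", "first", "only" and "open" are said of these compounds alone.

Measured so far in a functional assay on SW-620 cells (Homo sapiens) for cytotoxicity, read by MTT assay, with a stated time of 72 h; a lower number here means a stronger inhibitor, a higher number a weaker inhibitor:
compound 1 `COc1cccc(/C=C2\CCC/C(=C\c3ccccc3Br)C2=O)c1OC` gives 12100 nM
compound 2 `COc1cccc(/C=C2\CCC/C(=C\c3cccc(Br)c3)C2=O)c1OC` gives 8800 nM
compound 3 `COc1cccc(/C=C2\CCC/C(=C\c3ccc(Br)cc3)C2=O)c1OC` gives 11100 nM

The three measured compounds share one core and differ only in where the bromine sits on the second aryl ring. All three steps among them stay within the scatter: a 1.4-fold lower number from compound 1 to compound 2 (0.14 log units; within the scatter), a 1.1-fold lower number from compound 1 to compound 3 (0.04 log units; within the scatter) and a 1.3-fold higher number from compound 2 to compound 3 (0.10 log units; within the scatter). Compound 3 therefore stands among numbers that cannot be told apart; its nearest neighbour is compound 1 and its furthest is compound 2, and neither gap is beyond the scatter.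

Compound 4 `COc1cccc(/C=C2\CCC/C(=C\c3ccc(Cl)cc3Cl)C2=O)c1OC` is not yet measured. Relative to compound 3 the change is 2,4-dichlorophenyl in place of 4-bromophenyl on a double-bonded chain carbon bound to a double-bonded ring carbon. For the measured compounds named here, no measured step concerns a ring carrying two halogens, and no measured step swaps bromine for chlorine; the only steps at hand move a single bromine around the ring, and none of them moves this assay beyond the scatter. The nearest guide is that three halogenated aryl rings on this core all land in the same band, so compound 4 is expected to land there too, with the step of a 1.1-fold lower number from compound 3 to compound 4 (0.05 log units; within the scatter) estimated as no change beyond the scatter. Compound 4 is therefore estimated at 10000 nM, within 4000 nM to 25000 nM.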

Compound 4, half-maximal inhibitory concentration: 16300 nM
Compound 4: the middle estimate sits 1.6-fold (0.21 log units) below what was measured; the measured number falls inside the stated range.
By their numbers in this assay, from the lowest: compounds 2, 3, 1 and 4 (each within the scatter of the next).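

In this assay, 2,4-dichlorophenyl on a double-bonded chain carbon bound to a double-bonded ring carbon cannot be told apart from any of the three bromophenyl groups: (a 1.5-fold higher number from compound 3 to compound 4 (0.17 log units; within the scatter)), (a 1.9-fold higher number from compound 2 to compound 4 (0.27 log units; within the scatter)) and (a 1.3-fold higher number from compound 1 to compound 4 (0.13 log units; within the scatter)). The earlier compounds shown here showed only that moving one bromine around the aryl ring leaves the number within the scatter; this result extends that observation to a change of halogen and to a ring carrying two halogens, so all four compounds form one band on the shared core. No supporting data are available to explain this flat response.

Every substituent shown on this aryl ring is a halogen, so it remains open whether a group of another kind at this place, such as an amine, a carboxylic acid or a longer alkyl chain, would move the number beyond the scatter. As far as these compounds go, the other aryl ring, with its two methoxy groups, stays the same throughout, so its contribution to the values in this assay also remains open.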